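From a Urea to an Amide on a Diaryl Ether

A few compounds are considered here, and "the series" means these few. Any claim that something is new, unique, unknown or untested is made for them only; others in the source may bear on it.

Compound 1 `C[C@@H](NC(=O)Nc1ccc(Oc2ccc(C#N)cc2)cc1)c1cccc2ccccc12` reaches only the limit of > 15000 nM in a functional assay on PLC5 cells (Homo sapiens) for inhibition, read by MTT assay, with a stated time of 24 h (on this read-out higher numbers stand for weaker inhibition and lower numbers for stronger inhibition), a limit rather than a number. Among the compounds with values here, compound 2 `N#Cc1ccc(Oc2cccc(NC(=O)Nc3cccc(F)c3)c2)cc1` gives 3300 nM in this assay, the only real number among the two measured compounds. The other value, that of compound 1, is a limit (the limit of > 15000 nM in this assay, at which 1 of the 2 values shown sits). Compound 3 `N#Cc1ccc(Oc2cccc(NC(=O)c3ccccc3)c2)cc1` carries phenyl in place of (3-fluorophenyl)amino on a carbonyl carbon. Within the data shown here, no measured pair shows the size of such a change, so the expectation is a modest loss of potency, with the estimated step from compound 2 to compound 3 being a 2.4-fold higher number from compound 2 to compound 3 (0.38 log units; beyond the scatter). Compound 3 is therefore expected to give about 8000 nM, within a range from 2500 nM to 25000 nM.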

Compound 3, half-maximal inhibitory concentration: > 15000 nM
Compound 3 gave a limit, no number; the forecaster's own chance of this, stated with the estimate: 35%; middle value at least 1.8-fold (0.27 log units) from the limit.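

On a carbonyl carbon, phenyl in place of (3-fluorophenyl)amino gives an at least 4.5-fold higher number from compound 2 to compound 3 (0.65 log units; beyond the scatter) in this assay, so at this position the change costs clear potency. The true size of the step stays unknown because compound 3, like compound 1, reaches only a limit and not a number: the limit of > 15000 nM in this assay, at which 2 of the 3 values shown sit.

The nitrogen with its hydrogen and the fluorine leave together in this one change, so the loss cannot be assigned to either. A plain phenylamino group on the same carbonyl carbon would separate the two.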